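Oxetanyl-methylpyrazole in place of the trifluoromethyl pyrazole

The source may hold more compounds than are shown below. What is called first, only, known or untested is meant among the compounds shown, and "the series" means these compounds.

In an assay on HEK293 cells for inhibition of Leucine-rich repeat serine/threonine-protein kinase 2 variant G2019S (Homo sapiens), with a stated time of 48 h (on this read-out lower numbers stand for stronger inhibition and higher numbers for weaker inhibition), three compounds sharing one core have been measured. Compound 1 `Cc1c(Nc2nc(N)c3c(C#N)c(N4CCC[C@H]4C)n(C)c3n2)cnn1[C@@H]1CCOC1` gives 80 nM. Compound 3 `Cc1c(Nc2nc(N)c3c(C#N)c(N4CCC[C@H]4C)n(C)c3n2)cnn1[C@H]1CCOC1` gives 51 nM. Compound 2 `C[C@@H]1CCCN1c1c(C#N)c2c(N)nc(Nc3cn(C)nc3C(F)(F)F)nc2n1C` gives 460 nM and so stands highest of the three numbers, beyond the scatter from both others. Among the measured compounds shown here, the only measured single step is a 1.6-fold lower number from compound 1 to compound 3 (0.20 log units; within the scatter), and it rests on the fact that compounds 1 and 3 differ only in the configuration as drawn alone, so it says nothing about the substituent on the pyrazole.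

Compound 4 `Cc1nn(C2COC2)cc1Nc1nc(N)c2c(C#N)c(N3CCC[C@H]3C)n(C)c2n1` has not yet been measured in this assay. It differs from compound 2 by 3-methyl-1-(oxetan-3-yl)-1H-pyrazol-4-yl in place of 1-methyl-3-(trifluoromethyl)-1H-pyrazol-4-yl on a nitrogen on an aromatic ring. For the measured compounds named here, no measured step covers this change; compounds 1 and 3 differ from compound 2 in more than one place, so their values only show that a methyl-bearing pyrazole with a saturated oxygen ring on its nitrogen gave lower numbers than the trifluoromethyl pyrazole of compound 2. On that basis compound 4, which carries the methyl and an oxygen ring of similar kind, is expected to move toward the numbers of compounds 1 and 3, and the expected step is a 4.2-fold lower number from compound 2 to compound 4 (0.62 log units; beyond the scatter). The estimate for compound 4 is therefore 110 nM, within a range from 40 nM to 320 nM.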

Compound 4, half-maximal inhibitory concentration: 140 nM
Compound 4: the middle estimate sits 1.3-fold (0.10 log units) below what was measured; the range from low to high includes it.
By their numbers in this assay, from the lowest: compounds 3, 1 and 4 (each within the scatter of the next, the first and the last beyond it); then compound 2.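

In this assay, among the compounds shown here, the change to 3-methyl-1-(oxetan-3-yl)-1H-pyrazol-4-yl now has a direct reading on the shared core, with only this group differing, and it is a modest gain: a 3.3-fold lower number from compound 2 to compound 4 (0.52 log units; beyond the scatter). The earlier compounds shown here differed from compound 2 in more than one place, so they could not isolate the group on the aromatic nitrogen, whereas this single change shows that the 1-methyl-3-(trifluoromethyl)-1H-pyrazol-4-yl group of compound 2 can be replaced with a lower number as the result. Nothing shown here measures a property that would explain this step.

The change moves the trifluoromethyl, the methyl and the oxetane together, so the compounds shown do not tell how much of the step belongs to each of them. From the compounds shown here alone, it also remains open how the same position would respond to a plain ethyl chain, a longer chain such as 2-methoxyethyl, or an amine such as piperidin-4-yl on the pyrazole nitrogen.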